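Compound 3 and a ring-free chain in a tracheal assay

The source may hold more compounds than are shown below. What is called first, only, known or untested is meant among the compounds shown, and "the series" means these compounds.

Measured so far in a functional assay (trachea) with Cavia porcellus as the target; on this read-out higher numbers stand for weaker inhibition and lower numbers for stronger inhibition:
compound 1 `CCn1nc(-c2cccnc2)c2ccccc2c1=O`: 1320 nM
compound 2 `C=CCn1nc(-c2cccnc2)c2ccccc2c1=O`: 2140 nM
compound 3 `O=c1c2ccccc2c(-c2cccnc2)nn1CC1CCCCC1`: 209 nM

Compound 3 has the lowest number of the three, and its steps to both others lie beyond the scatter, so it is the strongest inhibitor measured so far in this assay. The next molecule, compound 4 `CCOC(=O)CCCn1nc(-c2cccnc2)c2ccccc2c1=O`, keeps the shared core and changes one group on a saturated chain carbon bound to an aromatic nitrogen: 2-(ethoxycarbonyl)ethyl in place of cyclohexyl (2-(ethoxycarbonyl)ethyl in place of cyclohexyl on a saturated chain carbon bound to an aromatic nitrogen).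

Going by the values given here, three measured steps concern this same place. Vinyl in place of methyl gave a 1.6-fold higher number from compound 1 to compound 2 (0.21 log units; within the scatter), so those two small groups cannot be told apart here. Cyclohexyl in place of methyl gave a 6.3-fold lower number from compound 1 to compound 3 (0.80 log units; beyond the scatter), and cyclohexyl in place of vinyl gave a 10-fold lower number from compound 2 to compound 3 (1.01 log units; beyond the scatter). Among the compounds with values here, no measured compound carries a chain like 2-(ethoxycarbonyl)ethyl, so these steps offer only a rough guide. Compound 4 gives up the cyclohexyl ring, and the closest guide is the size of a 6.3-fold lower number from compound 1 to compound 3 (0.80 log units; beyond the scatter), run in reverse. A slightly smaller move toward weaker inhibition therefore seems likely. The expected change is a 4.3-fold higher number from compound 3 to compound 4 (0.63 log units; beyond the scatter). In this assay the estimated value for compound 4 is 900 nM, with an expected range of 280 nM to 2900 nM.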

Compound 4, half-maximal inhibitory concentration: 10000 nM
For compound 4 the middle estimate is 11-fold (1.05 log units) below the measured one, outside the stated range (above it).
By their numbers in this assay, from the lowest: compound 3; then compounds 1 and 2 (each within the scatter of the next); then compound 4.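

In this assay, going by these compounds alone, the earlier compounds showed only that cyclohexyl gave lower numbers than the two small groups, which left room to think that any larger group at this place would do the same. Compound 4 rules that out for this chain: 2-(ethoxycarbonyl)ethyl in place of cyclohexyl gives a 48-fold higher number from compound 3 to compound 4 (1.68 log units; beyond the scatter) and the ring's advantage is lost entirely. The chain also falls behind the small groups, with a 4.7-fold higher number from compound 2 to compound 4 (0.67 log units; beyond the scatter) and a 7.6-fold higher number from compound 1 to compound 4 (0.88 log units; beyond the scatter) in the comparisons with them, so compound 4 is the weakest inhibitor of the four and this position can push the number in either direction, though nothing shown here accounts for that.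

Compound 4 loses the ring and gains the ester in a single change, so the compounds shown leave open which of the two matters more. A plain longer chain of carbon only would separate those two changes, and a carboxylic acid in place of the ethyl ester would show whether the outcome depends on the ester itself.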